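The compounds below may be only part of what the source reports. "The series", "measured", "known", "first", "only" and "open" are said of these compounds alone.

The measured compounds:
Compound 1 `O=C1N=C(N2CCC[C@H]2C(=O)Nc2ccc3ncnc(Nc4cccc(Cl)c4)c3c2)S/C1=C/c1ccc(Br)s1`: > 50000 nM
Compound 2 `COc1ccc(/C=C2/SC(N3CCC[C@H]3C(=O)Nc3ccc4ncnc(Nc5cccc(Cl)c5)c4c3)=NC2=O)cc1`: 19000 nM
Compound 3 `Cc1cccc(/C=C2/SC(N3CCC[C@H]3C(=O)Nc3ccc4ncnc(Nc5cccc(Cl)c5)c4c3)=NC2=O)n1`: 4500 nM

All three share one core and differ only in the aromatic group on a double-bonded chain carbon bound to a double-bonded ring carbon. In a functional assay on HepG2 cells (Homo sapiens) for antiproliferative activity, read by MTT assay (a lower number here means a stronger inhibitor, a higher number a weaker inhibitor), compound 1 gives > 50000 nM. That value is a limit of the assay, not a number, so compound 1 sits at the weak edge of what the assay can report (the limit of > 50000 nM in this assay, at which 1 of the 3 values shown sits). Replacing its 5-bromothiophen-2-yl group gave measurable numbers in both cases: an at least 2.6-fold lower number from compound 1 to compound 2 (0.42 log units; beyond the scatter) and an at least 11-fold lower number from compound 1 to compound 3 (1.04 log units; beyond the scatter), while a 4.2-fold lower number from compound 2 to compound 3 (0.63 log units; beyond the scatter) sets the two replacements apart from each other.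

Compound 4 `O=C1N=C(N2CCC[C@H]2C(=O)Nc2ccc3ncnc(Nc4cccc(Cl)c4)c3c2)S/C1=C/c1cccc(Br)c1` is not yet measured. It differs from compound 1 in one place: 3-bromophenyl in place of 5-bromothiophen-2-yl on a double-bonded chain carbon bound to a double-bonded ring carbon. The entering group is a six-membered ring of carbon only, as in compound 2, carrying a bromine rather than a methoxy group. Both measured replacements of the 5-bromothiophen-2-yl group lowered the number, so a lower number is expected for compound 4 as well, of a size close to the step seen for compound 2, an at least 2.6-fold lower number from compound 1 to compound 2 (0.42 log units; beyond the scatter). The expected step is an at least 2.5-fold lower number from compound 1 to compound 4 (0.39 log units; beyond the scatter). In this assay compound 4 is estimated at 20000 nM, within a range from 7000 nM to 60000 nM.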

Compound 4, half-maximal inhibitory concentration: 21300 nM
Compound 4: middle estimate off by 1.1-fold (0.03 log units), on the low side; low and high end bracket the measured number.
By their numbers in this assay, from the lowest: compound 3; then compounds 2 and 4 (each within the scatter of the next). At a limit, above all of these: compound 1.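

In this assay compound 1 carries a limit of the assay, not a number: the limit of > 50000 nM in this assay, at which 1 of the 4 values shown sits.

Compound 4 keeps a bromine but has a six-membered aromatic ring of carbon only in place of the five-membered aromatic ring with 1 hetero atom, and this gives an at least 2.3-fold lower number from compound 1 to compound 4 (0.37 log units; beyond the scatter), so a bromine on the aromatic group does not by itself hold a compound at that limit. The two compounds with a six-membered ring of carbon only cannot be told apart, with a 1.1-fold higher number from compound 2 to compound 4 (0.05 log units; within the scatter), while the 6-methylpyridin-2-yl group of compound 3 remains clearly separate, with a 4.7-fold higher number from compound 3 to compound 4 (0.68 log units; beyond the scatter).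

Still open, as far as these compounds go, is whether the weak result of compound 1 goes with the thiophene ring or with its bromine, a question that a plain thiophen-2-yl group and a plain phenyl group could help to settle. Also open, from the compounds shown here alone, is whether the ring nitrogen or the methyl group of the 6-methylpyridin-2-yl group goes with the lower number of compound 3, which a pyridin-2-yl group without the methyl could help to separate.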